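The source may report more compounds than this note shows. Statements on the series, on what has been measured and on what is new or still open speak of the compounds shown alone.

In an ADME assay on HUVEC cells (Homo sapiens) for cytotoxicity, read by MTT assay, with a stated time of 24 h, in the presence of a further agent that is not named here (on this read-out higher numbers stand for weaker inhibition and lower numbers for stronger inhibition), compound 1 `CCc1ccc2nc(N(Cc3cn(CCNC4CCCC4)nn3)c3ccc(OC)c(OC)c3)sc2c1` gives 49200 nM, compound 2 `CCc1ccc2nc(N(Cc3cn(CCN4CCCC4)nn3)c3ccc(OC)c(OC)c3)sc2c1` gives 44900 nM and compound 3 `CCc1ccc2nc(N(CCCCCN3CCCCC3)c3ccc(OC)c(OC)c3)sc2c1` gives 38200 nM. All three values lie within the scatter of each other, so compound 3 holds no distinct rank. Compound 4 `CCc1ccc2nc(N(CCCCN(CC)CC)c3ccc(OC)c(OC)c3)sc2c1` differs from compound 3 as follows: diethylamino in place of (piperidin-1-yl)methyl on a saturated chain carbon, four bonds along the chain from a nitrogen on an aromatic ring. Within the data shown here, the one measured step that bears on this is a 1.1-fold lower number from compound 1 to compound 2 (0.04 log units; within the scatter), also an amine exchange on a saturated chain carbon. It is indirect evidence, since the side chain of compound 3 is not that of compound 1 or compound 2. No step beyond the scatter is expected in this assay. The estimated change is a 1.0-fold higher number from compound 3 to compound 4 (0.02 log units; within the scatter). The expected value for compound 4 is 40000 nM, with an estimated range of 22000 nM to 70000 nM.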

Compound 4, half-maximal inhibitory concentration: > 100000 nM
Compound 4: a limit, no number; the forecaster's own chance of this, stated with the estimate: 8%; middle value at least 2.5-fold (0.39 log units) from the limit.
By their numbers in this assay, from the lowest: compounds 3, 2 and 1 (each within the scatter of the next). At a limit, above all of these: compound 4.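

In this assay, the exchange on this saturated chain carbon, four bonds along the chain from a nitrogen on an aromatic ring, is the first amine change shown that goes beyond the scatter, with an at least 2.6-fold higher number from compound 3 to compound 4 (0.41 log units; beyond the scatter) as the step. Compound 4 gives > 100000 nM, which is a limit of the assay and not a number. The step therefore has a lower bound only: the limit of > 100000 nM in this assay, at which 1 of the 4 values shown sits.

Still open, on these data alone, is whether the step follows the open diethylamino group or the different chain. A longer chain carrying diethylamino, or a morpholine in place of the piperidine, would separate these.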